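The source may hold more compounds than are shown below. What is called first, only, known or untested is meant among the compounds shown, and "the series" means these compounds.

Compound 1 `Cc1ccc(-c2cn(C/C=C3\OC(=O)C(OCc4ccccc4)=C3OCc3ccccc3)nn2)cc1`: > 100000 nM
Compound 2 `COc1ccccc1-c1cn(C[C@H](O)[C@H]2OC(=O)C(OCc3ccccc3)=C2OCc2ccccc2)nn1`: 50 nM
Compound 3 `COc1ccc(-c2cn(C/C=C3\OC(=O)C(OCc4ccccc4)=C3OCc3ccccc3)nn2)cc1`: > 100000 nM

Of the compounds shown here, three have been measured in an ADME assay on HFF cells (Homo sapiens) for cytotoxicity, read by MTT assay, with a stated time of 72 h; a higher number here means a weaker inhibitor, a lower number a stronger inhibitor. Compound 1 gives only a limit of the assay, > 100000 nM, and not a number. Compound 3 likewise gives only a limit, > 100000 nM. Among the measured compounds shown here, compound 2 gives the single actual number in this assay, 50 nM, and so stands as the one compound with a readable value. The step that the two limits leave unreadable from compound 1 to compound 3 cannot be sized, because both ends sit at the limit of > 100000 nM in this assay, at which 2 of the 3 values shown sit.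

Compound 4 `C[Si](C)(C)c1cn(C[C@H](O)[C@H]2OC(=O)C(OCc3ccccc3)=C2OCc2ccccc2)nn1` is not yet measured. It differs from compound 2 in one place: a group of 4 heavy atoms (3 carbon, 1 silicon; no ring) in place of a group of 8 heavy atoms (7 carbon, 1 oxygen; one six-membered aromatic ring of carbon only), on an aromatic carbon. For the measured compounds named here, no measured step changes the group on this position of the triazole ring in a way that can be read, and compounds 1 and 3 share neither the hydroxy group nor the saturated lactone of compound 2, so the only direct evidence is the value of compound 2 itself.

With no readable step to lean on, the expectation for compound 4 is set near compound 2 with a wide range, and the estimated step of a 4.0-fold higher number from compound 2 to compound 4 (0.60 log units; beyond the scatter) is small. Compound 4 is therefore estimated at 200 nM, within 30 nM to 5000 nM.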

Compound 4, half-maximal inhibitory concentration: 20000 nM
Estimate against measurement, compound 4: 100-fold (2.00 log units) below, and the stated range ends below it.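

In this assay, putting the group of 4 heavy atoms (3 carbon, 1 silicon; no ring) in place of 2-methoxyphenyl on this aromatic carbon of the five-membered aromatic ring with 3 nitrogen gives a 400-fold higher number from compound 2 to compound 4 (2.60 log units; beyond the scatter). Among the compounds shown here, this is the first readable step at this position, and it shows that the group held there can by itself shift the reading by far more than the usual scatter, with the rest of the molecule unchanged; the change makes the compound a much weaker inhibitor of these cells. Compounds 1 and 3 give only a limit and not a number, so the step between them cannot be read, whereas compound 4 still has a real value: the limit of > 100000 nM in this assay, at which 2 of the 4 values shown sit.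

A single replacement cannot show whether the large step follows from losing the aromatic ring, from losing the oxygen of the methoxy group, or from bringing in silicon. A plain phenyl group would test the first two, and a tert-butyl group, which has carbon where compound 4 has silicon, would test the third.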